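The source may hold more compounds than are shown below. What is called first, only, known or untested is meant among the compounds shown, and "the series" means these compounds.

The three measured compounds share one core and differ only in the group attached to it. Compound 1 `COc1nc2ccc(Br)cc2cc1C(c1ccccc1)n1cc(-c2ccc(OC(F)(F)F)cc2)nn1` carries a 4-(trifluoromethoxy)phenyl, and in an ADME assay on HEK293 cells (Homo sapiens) for cytotoxicity, read by sulforhodamine B assay, with a stated time of 48 h, tested at 10 uM (on this read-out lower numbers stand for less inhibition and higher numbers for more inhibition at the one concentration tested (going by the name of the read-out)), compound 1 gives 5.8%. Compound 2 `CCCCCCCCc1cn(C(c2ccccc2)c2cc3cc(Br)ccc3nc2OC)nn1` carries an octyl and in this assay compound 2 gives 14.6%. Compound 3 `COc1nc2ccc(Br)cc2cc1C(c1ccccc1)n1cc(CO)nn1` carries a hydroxymethyl and in this assay compound 3 gives 11.5%, the second highest of the three numbers, with compound 2 nearest and compound 1 furthest. Every step among them stays within the scatter: a number 8.8 percentage points higher from compound 1 to compound 2 (within the scatter), a number 5.7 percentage points higher from compound 1 to compound 3 (within the scatter) and a number 3.1 percentage points lower from compound 2 to compound 3 (within the scatter).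

Compound 4 `CCCCCc1cn(C(c2ccccc2)c2cc3cc(Br)ccc3nc2OC)nn1` has not yet been measured. It differs from compound 3 as follows: butyl in place of hydroxy on a saturated chain carbon bound to an aromatic carbon. The step that bears most directly on this change runs from compound 2 to compound 3, where hydroxy took the place of heptyl on a saturated chain carbon bound to an aromatic carbon and the read-out moved a number 3.1 percentage points lower from compound 2 to compound 3 (within the scatter); compound 4, with its butyl, sits between those two in chain length. Since the other two steps, a number 8.8 percentage points higher from compound 1 to compound 2 (within the scatter) and a number 5.7 percentage points higher from compound 1 to compound 3 (within the scatter), likewise stay within the scatter, compound 4 is expected to show no step beyond the scatter, a number 1.5 percentage points higher from compound 3 to compound 4 (within the scatter). Compound 4 is therefore estimated at 13%, within a range from 4% to 22%.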

Compound 4, a percentage reported as inhibition, at one concentration (the size of the read-out at that concentration, not a potency): -2%
The estimate for compound 4 lay 15 percentage points above the measured number, outside the stated range (below it).
By their numbers in this assay, from the lowest: compounds 4, 1, 3 and 2 (each within the scatter of the next, the first and the last beyond it).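

Among the compounds shown here, the change of butyl in place of hydroxy on a saturated chain carbon bound to an aromatic carbon gives the first steps at this position that clear the scatter in this assay: a number 13.5 percentage points lower from compound 3 to compound 4 (beyond the scatter), and hydrogen in place of propyl on the longer chain gives a number 16.6 percentage points lower from compound 2 to compound 4 (beyond the scatter). Among these three compounds, the read-out therefore does not follow chain length, since the pentyl of compound 4 falls clearly apart from both the hydroxymethyl of compound 3 and the octyl of compound 2, while those two remain within the scatter of each other, and the pentyl cannot be told apart from the 4-(trifluoromethoxy)phenyl, with a number 7.8 percentage points lower from compound 1 to compound 4 (within the scatter). Nothing available gives a measured reason for this uneven behaviour.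

On these data alone, what stays open is whether the low reading belongs to the pentyl alone or extends to neighbouring chains such as propyl or hexyl, which would show whether it is a narrow dip or a broader stretch of the series. As far as these compounds go, it is also open how an amine or a carboxylic acid at the end of the chain would read in this assay, compared with the hydroxymethyl of compound 3.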